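Swapping a Branched Alkyl for a Chlorinated Ring

The source may hold more compounds than are shown below. What is called first, only, known or untested is meant among the compounds shown, and "the series" means these compounds.

Compound 1, `O=C(O)c1ccccc1-c1ccc(CCc2ncc(CC3CCC3)[nH]2)cc1`, gives 588 nM in an in vitro functional assay on cells for agonist activity at Bombesin receptor subtype-3 (Homo sapiens), read by luminescence and calcium flux; on this read-out higher numbers stand for an effect only at larger amounts of compound and lower numbers for an effect already at smaller amounts.
Compound 2, `CC(C)(C)CCc1cnc(CCc2ccc(-c3ccccc3C(=O)O)cc2)[nH]1`, gives 39 nM.
Compound 3, `CC(C)(C)Cc1cnc(CCc2ccc(-c3ccccc3C(=O)O)cc2)[nH]1`, gives 106 nM.

All three share one core and differ only in the group on a saturated chain carbon bound to an aromatic carbon. Compound 3 sits second highest of the three numbers: compared with its nearest neighbour the change is a 2.7-fold higher number from compound 2 to compound 3 (0.43 log units; beyond the scatter), and compared with the furthest it is a 5.5-fold lower number from compound 1 to compound 3 (0.74 log units; beyond the scatter).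

Compound 4, `O=C(O)c1ccccc1-c1ccc(CCc2ncc(Cc3ccccc3Cl)[nH]2)cc1`, has not yet been measured. The change from compound 3 is 2-chlorophenyl in place of tert-butyl on a saturated chain carbon bound to an aromatic carbon.

The steps seen so far all exchange small saturated groups at this position: a 15-fold lower number from compound 1 to compound 2 (1.18 log units; beyond the scatter), a 5.5-fold lower number from compound 1 to compound 3 (0.74 log units; beyond the scatter) and a 2.7-fold higher number from compound 2 to compound 3 (0.43 log units; beyond the scatter). Together they show that this position tolerates change and that larger groups have so far given lower numbers, with compound 1 carrying the smallest ring-containing group and the highest number. Going by the values given here, none of the measured steps brings in an aromatic ring or a chlorine, so no direct guide exists. The 2-chlorophenyl group is larger than tert-butyl, which leans towards a somewhat lower number, but the direction is uncertain.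

Compound 4 is therefore expected to land close to compound 3, with an estimated step of a 1.3-fold lower number from compound 3 to compound 4 (0.12 log units; within the scatter). The estimate for compound 4 is 80 nM, with a range from 20 nM to 400 nM.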

Compound 4, half-maximal effective concentration: 292 nM
Beside the measured number, compound 4's estimate is 3.7-fold (0.56 log units) below it; measured number inside the range.
By their numbers in this assay, from the lowest: compound 2; then compound 3; then compounds 4 and 1 (each within the scatter of the next).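

Putting the first aromatic ring and the first chlorine on this saturated chain carbon bound to an aromatic carbon gives a 2.8-fold higher number from compound 3 to compound 4 (0.44 log units; beyond the scatter) in this assay and a 7.5-fold higher number from compound 2 to compound 4 (0.87 log units; beyond the scatter) in the same assay, so the move from a branched alkyl group to 2-chlorophenyl is not neutral here. The earlier idea that a bigger group brings a lower number therefore fails: 2-chlorophenyl has more heavy atoms than tert-butyl, yet compound 4 goes against that trend, and heavy-atom count alone does not order these compounds. The last comparison shows a 2.0-fold lower number from compound 1 to compound 4 (0.30 log units; within the scatter) and so cannot separate the 2-chlorophenyl group from cyclobutyl, while nothing available gives a reason for any of these shifts.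

The compounds shown do not separate the effect of the aromatic ring from that of the chlorine, and a plain phenyl group at this place would be the direct comparison. Also open, on these data alone, is how a longer branched chain than neopentyl, or a cyclohexyl ring, would compare with compound 2 in this assay and whether either could bring the number lower still.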